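The source may hold more compounds than are shown below. What is called first, only, known or untested is meant among the compounds shown, and "the series" means these compounds.

Among the measured compounds shown here, in an ADME assay on Vero cells (Homo sapiens) for cytotoxicity against Vero (Chlorocebus sabaeus), read by MTT assay (a higher number here means that more compound is tolerated, a lower number that less compound is tolerated), the entry for compound 1 `CC(C)c1cc(C(C)C)c(S(=O)(=O)Nc2cccc3cccnc23)c(C(C)C)c1` reads "not determined" (no result reported), so compound 2 `O=S(=O)(Nc1cccc2cccnc12)c1ccc(-c2ccccc2)cc1`, at 245000 nM, holds the only number and cannot yet be ranked against another compound. Compound 3 `O=S(=O)(Nc1cccc2cccnc12)c1ccc(Br)cc1` differs from compound 2 in one place: bromo in place of phenyl on an aromatic carbon, with bromo in place of phenyl on an aromatic carbon. For the measured compounds named here, no measured pair shows what this swap does in this assay, so the expectation rests on compound 2 alone, at 245000 nM. The expected step is a 1.4-fold lower number from compound 2 to compound 3 (0.13 log units; within the scatter), slightly downward and within the usual scatter. For compound 3 the estimated value is 180000 nM, with an expected range of 60000 nM to 450000 nM.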

Compound 3, half-maximal cytotoxic concentration: 88700 nM
For compound 3 the middle estimate is 2.0-fold (0.31 log units) above the measured one, within the range that was stated.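

In this assay, putting bromo in place of phenyl, para to a large group, gives a 2.8-fold lower number from compound 2 to compound 3 (0.44 log units; beyond the scatter). This first measured pair shows that this position is not indifferent to the swap: compound 3, with bromo, is tolerated only at a lower concentration than compound 2, with phenyl. Nothing measured here explains the shift. A single pair gives one direction for one swap, not a trend across this position. As far as these compounds go, whether an amine, a carboxylic acid or a longer chain at the same place would bring the number closer to compound 2 or to compound 3 remains open.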